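A Second Chloro on the Benzyl Group

The compounds below may be only part of what the source reports. "The series", "measured", "known", "first", "only" and "open" are said of these compounds alone.

Compound 1 `N#Cc1ccccc1CN1CCc2c(sc(NC(=O)c3ccccc3Cl)c2C(N)=O)C1`: 10400 nM
Compound 2 `NC(=O)c1c(NC(=O)c2ccccc2Cl)sc2c1CCN(Cc1ccc(Cl)cc1)C2`: 22500 nM

In a functional assay on HL-60 cells (Homo sapiens) for antiproliferative activity, with a stated time of 24 h (a higher number here means a weaker inhibitor, a lower number a stronger inhibitor), compound 2 gives the higher of the two numbers, 22500 nM, which makes it the weaker inhibitor. Compound 3 `NC(=O)c1c(NC(=O)c2ccccc2Cl)sc2c1CCN(Cc1ccc(Cl)cc1Cl)C2` changes it in one place: chloro in place of hydrogen on an aromatic carbon. This turns 4-chlorobenzyl into 2,4-dichlorobenzyl. Going by the values given here, only one measured step bears on this part of the molecule, a 2.2-fold higher number from compound 1 to compound 2 (0.34 log units; beyond the scatter), and it was modest. Among the compounds with values here, that step swapped one substituted ring for another, and no measured pair shows a direction for an added chloro, so little change beyond the scatter is expected. The expected step is a 1.1-fold lower number from compound 2 to compound 3 (0.05 log units; within the scatter). Compound 3 is estimated at 20000 nM, with an expected range from 9000 nM to 45000 nM.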

Compound 3, half-maximal inhibitory concentration: 8010 nM
Estimate against measurement, compound 3: 2.5-fold (0.40 log units) above; the whole stated range lies above it.
By their numbers in this assay, from the lowest: compounds 3 and 1 (each within the scatter of the next); then compound 2.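

In this assay, adding a chloro to the 4-chlorobenzyl group gives a 2.8-fold lower number from compound 2 to compound 3 (0.45 log units; beyond the scatter), showing that this ring carbon responds to a single added atom. The 2,4-dichlorophenyl and 2-cyanophenyl groups cannot be told apart here, with a 1.3-fold lower number from compound 1 to compound 3 (0.11 log units; within the scatter), so two different rings can give a similar result. No available evidence gives a cause for these steps. Going by these compounds, whether a methyl, a methoxy group or an amine on this same ring carbon would give a similar step remains open.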